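Opening the oxolane side chain: compound 2 to compound 3

A few compounds are considered here, and "the series" means these few. Any claim that something is new, unique, unknown or untested is made for them only; others in the source may bear on it.

Compound 1 `Nc1nc2cc(-c3nn(C[C@H]4CCCO4)c4ncnc(N)c34)ccc2o1`: 100 nM
Compound 2 `Nc1nc2cc(-c3nn(C[C@@H]4CCCO4)c4ncnc(N)c34)ccc2o1`: 100 nM

In a functional assay on T98 cells (Homo sapiens) for antiproliferative activity, with a stated time of 5 days (a higher number here means that more compound is needed for the effect, a lower number that less compound is needed), compound 1 and compound 2 stand level, with compound 2 at 100 nM. Compound 3 `COC(Cn1nc(-c2ccc3oc(N)nc3c2)c2c(N)ncnc21)OC` has dimethoxymethyl in place of oxolan-2-yl on a saturated chain carbon bound to an aromatic nitrogen. Going by the values given here, the only measured step, no change at the digits printed from compound 1 to compound 2 (within the scatter), involves configuration alone (the fact that compounds 1 and 2 differ only in the configuration as drawn), and no measured step removes the ring. A step within the scatter is therefore expected in this assay, leaning slightly towards higher values, but this is weakly supported. The estimated step is a 1.5-fold higher number from compound 2 to compound 3 (0.18 log units; within the scatter). The expected value for compound 3 is 150 nM, with an estimated range of 40 nM to 500 nM.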

Compound 3, half-maximal effective concentration: 100 nM
Compound 3: the middle estimate sits 1.5-fold (0.18 log units) above what was measured; low and high end bracket the measured number.
By their numbers in this assay, from the lowest: compounds 1, 2 and 3 (each within the scatter of the next).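

In this assay, the step to the open dimethoxymethyl group on a saturated chain carbon bound to an aromatic nitrogen gives no change at the digits printed from compound 2 to compound 3 (within the scatter), and the other ring configuration gives no change at the digits printed from compound 1 to compound 3 (within the scatter). Compound 3 has no ring and no defined stereocentre at this place, so across these three compounds neither feature is needed to keep the value at this level. The earlier pair could speak only to configuration: the fact that compounds 1 and 2 differ only in the configuration as drawn

The compounds shown leave open how far this place accepts groups of a different kind, such as an amine, a carboxylic acid or a longer chain.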